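Adding a chloro to compound 3

The source may hold more compounds than are shown below. What is called first, only, known or untested is meant among the compounds shown, and "the series" means these compounds.

In a functional assay on U-251 cells (Homo sapiens) for antiproliferative activity, read by MTT assay, with a stated time of 72 h (a lower number here means a stronger inhibitor, a higher number a weaker inhibitor), compound 1 `O=C1C=C(N2CCN(c3ccccc3Cl)CC2)C(=O)c2ccccc21` gives 30800 nM, compound 2 `Cc1ccccc1N1CCN(C2=CC(=O)c3cccc(O)c3C2=O)CC1` gives 10200 nM, and compound 3 `O=C1C=C(N2CCC(c3ccccc3)CC2)C(=O)c2c(O)cccc21` gives 10800 nM. Compound 3 therefore sits level with compound 2, within the scatter, and has a clearly lower number than compound 1, which makes it the stronger inhibitor of that pair. Compound 4 `O=C1C=C(N2CCC(c3ccc(Cl)cc3)CC2)C(=O)c2c(O)cccc21` is compound 3 with chloro in place of hydrogen on an aromatic carbon, para to a large group (chloro in place of hydrogen on an aromatic carbon). Going by the values given here, no measured pair shows what this change does, so only a small move toward a lower number, inside the scatter, is expected in this assay: a 1.5-fold lower number from compound 3 to compound 4 (0.19 log units; within the scatter). For compound 4 the estimated value is 7000 nM, with an expected range from 3000 nM to 16000 nM.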

Compound 4, half-maximal inhibitory concentration: 6100 nM
The estimate for compound 4 lay 1.1-fold (0.06 log units) above the measured number; low and high end bracket the measured number.
By their numbers in this assay, from the lowest: compounds 4, 2 and 3 (each within the scatter of the next); then compound 1.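

Going by these compounds alone, compound 3 and compound 4 form the first pair here that differs in only one place, so the effect of this change can now be read directly. In this assay, replacing phenyl with 4-chlorophenyl gives a 1.8-fold lower number from compound 3 to compound 4 (0.25 log units; within the scatter), so chloro is accepted at this place, para to a large group, without a change that can be told from the scatter. Nothing available explains this result.

Going by these compounds, it remains open whether a methoxy group or an amine at the same place would shift the number further. A single pair also cannot show whether chloro behaves the same way on other compounds.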